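The source may report more compounds than this note shows. Statements on the series, on what has been measured and on what is new or still open speak of the compounds shown alone.

Three compounds share one core and differ only in the group carried on a sulfur. Going by the values given here, compound 1 `CC(C)[C@H](NC(=O)COc1cccc2ccccc12)C(=O)N[C@@H](CC(=O)O)C(=O)CSC1=NCCS1` is the first of them. In a functional assay on Jurkat cells (Homo sapiens) for inhibition (on this read-out lower numbers stand for stronger inhibition and higher numbers for weaker inhibition), compound 1 gives > 200000 nM, which is a limit of the assay and not a number. Compound 2 `CC(C)[C@H](NC(=O)COc1cccc2ccccc12)C(=O)N[C@@H](CC(=O)O)C(=O)CSc1nc(-c2ccccc2)cs1` gives in this assay only a limit, > 200000 nM. Compound 3 `CC(C)[C@H](NC(=O)COc1cccc2ccccc12)C(=O)N[C@@H](CC(=O)O)C(=O)CSc1nc2ccccc2s1` likewise gives in this assay only a limit, > 200000 nM. Because all three values sit at the limit of > 200000 nM in this assay, at which 3 of the 3 values shown sit, none of the steps between them can be read: a step that the two limits leave unreadable from compound 1 to compound 2, a step that the two limits leave unreadable from compound 1 to compound 3 and a step that the two limits leave unreadable from compound 2 to compound 3. Compound 3 therefore stands nowhere distinct among the three; all that is known of it is that no inhibition was seen up to the limit.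

Compound 4 `CC(C)[C@H](NC(=O)COc1cccc2ccccc12)C(=O)N[C@@H](CC(=O)O)C(=O)COn1nnc2ccccc21` has not yet been measured. It differs from compound 3 by a group of 10 heavy atoms (6 carbon, 3 nitrogen, 1 oxygen; one five-membered aromatic ring with 3 hetero atoms, one six-membered aromatic ring of carbon only) in place of a group of 10 heavy atoms (7 carbon, 1 nitrogen, 2 sulfur; one five-membered aromatic ring with 2 hetero atoms, one six-membered aromatic ring of carbon only), on a saturated chain carbon bound to a carbonyl carbon. Among the compounds with values here, no measured step bears on this change, since every step among compound 1, compound 2 and compound 3 is unreadable, so neither a size nor a direction can be derived for this assay. With nothing to anchor a shift, the step from compound 3 to compound 4 is expected to be a number no higher from compound 3 to compound 4 (the limit leaves the size open), most probably ending again at a limit. Compound 4 is estimated at 200000 nM, within a range from 40000 nM to 400000 nM.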

Compound 4, half-maximal inhibitory concentration: > 200000 nM
Compound 4: a limit, no number (the forecaster's own chance of this, stated with the estimate: 75%); the middle value lies on the limit itself.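

In this assay compound 4 gives > 200000 nM, which is a limit and not a number. The steps from compound 1, compound 2 and compound 3 to compound 4 therefore cannot be read, because every value sits at the same limit: the limit of > 200000 nM in this assay, at which 4 of the 4 values shown sit.

Left open is how strongly any of these four compounds inhibits, and whether changing the group on the saturated chain carbon bound to a carbonyl carbon makes any difference in this assay.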